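This account rests on a few compounds, and the source may have more. Where it says the series, first, only, none or still open, it means among the compounds named here.

Measured compounds:
Compound 1 `CC(=O)CC1CC(=O)N(c2ccccc2)C1=O` gives 62400 nM in an assay on cells (1-87 tumor cell line) for inhibition of Polyunsaturated fatty acid 5-lipoxygenase (Homo sapiens), with a stated time of 5 min; on this read-out lower numbers stand for stronger inhibition and higher numbers for weaker inhibition.
Compound 2 `O=C1CCCC1C1CC(=O)N(c2ccccc2)C1=O` gives 98600 nM in this assay.

In this assay compound 2 holds the highest of the two numbers, and the nearest number is that of compound 1, a gap that lies within the scatter. Compound 3 `CC(=O)C(C)(C)C1CC(=O)N(c2ccccc2)C1=O` carries 1-acetyl-1-methylethyl in place of 2-oxocyclopentyl on a saturated ring carbon. Among the measured compounds shown here, the only measured step at this ring carbon is a 1.6-fold higher number from compound 1 to compound 2 (0.20 log units; within the scatter), which stays within the scatter; for compound 3 no step beyond the scatter is therefore expected in this assay. The estimate for compound 3 is 75000 nM, range 25000 nM to 220000 nM. This estimate means an expected step of a 1.3-fold lower number from compound 2 to compound 3 (0.12 log units; within the scatter).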

Compound 3, half-maximal inhibitory concentration: 53500 nM
Beside the measured number, compound 3's estimate is 1.4-fold (0.15 log units) above it; low and high end bracket the measured number.
By their numbers in this assay, from the lowest: compounds 3, 1 and 2 (each within the scatter of the next).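

In this assay, 1-acetyl-1-methylethyl in place of 2-oxocyclopentyl gives a 1.8-fold lower number from compound 2 to compound 3 (0.27 log units; within the scatter), and in place of 2-oxopropyl it gives a 1.2-fold lower number from compound 1 to compound 3 (0.07 log units; within the scatter). At this saturated ring carbon, then, removing the five-membered ring while keeping the heavy-atom count does not move the number beyond the scatter, and neither does the change from 2-oxopropyl. No supporting data bear on why these three compounds read alike.

Open, from the compounds shown here alone, is whether an amine or a carboxylic acid at this ring carbon would give a step beyond the scatter. Going by these compounds, the effect of substituents on the phenyl group also remains open.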